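The source may hold more compounds than are shown below. What is called first, only, known or untested is meant among the compounds shown, and "the series" means these compounds.

Measured in a functional assay on KB cells (Homo sapiens) for cytotoxicity, read by sulforhodamine B assay; on this read-out higher numbers stand for an effect only at larger amounts of compound and lower numbers for an effect already at smaller amounts:
- compound 1 `C=C1CC[C@@H]2[C@](C)(COC(C)=O)[C@H](OC(C)=O)CC[C@@]2(C)[C@@H]1C/C=C1/C(=O)OC[C@H]1OC(C)=O`: 11.6 uM
- compound 2 `C=C1CC[C@@H]2[C@](C)(CO)[C@H](OC(C)=O)CC[C@@]2(C)[C@@H]1C/C=C1/C(=O)OC[C@H]1OC(C)=O`: 11.7 uM
- compound 3 `C=C1CC[C@@H]2[C@](C)(CO[Si](C)(C)C(C)(C)C)[C@H](OC(C)=O)CC[C@@]2(C)[C@@H]1C/C=C1/C(=O)OC[C@H]1OC(C)=O`: 3.62 uM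

Compound 3 has the lowest number of the three. The steps leading to it are a 3.2-fold lower number from compound 1 to compound 3 (0.51 log units; beyond the scatter) and a 3.2-fold lower number from compound 2 to compound 3 (0.51 log units; beyond the scatter).

The next structure is compound 4 `C=C1CC[C@@H]2[C@](C)(CO[Si](C)(C)C(C)(C)C)[C@H](O)CC[C@@]2(C)[C@@H]1C/C=C1/C(=O)OC[C@H]1OC(C)=O`, which differs from compound 3 as follows: hydrogen in place of acetyl on an oxygen on a saturated carbon. The exchange is hydrogen in place of acetyl on an oxygen on a saturated carbon.

Among the compounds with values here, the one measured step of this kind lies at a different oxygen: a 1.0-fold higher number from compound 1 to compound 2 (0.00 log units; within the scatter). The larger steps above involve a different exchange and bear on this one only indirectly. No measurement covers the removal of acetyl at the oxygen concerned here, so the transfer from the earlier step is uncertain. No change beyond the scatter is therefore expected in this assay, and the range is kept wide.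

The estimated step is a 1.2-fold higher number from compound 3 to compound 4 (0.09 log units; within the scatter). Compound 4 is expected at 4.5 uM, within an estimated range of 2 uM to 10 uM.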

Compound 4, concentration for half-maximal effect: 10.7 uM
For compound 4 the middle estimate is 2.4-fold (0.38 log units) below the measured one; measured number above the stated range.
By their numbers in this assay, from the lowest: compound 3; then compounds 4, 1 and 2 (each within the scatter of the next).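

In this assay, the exchange of acetoxy to hydroxy on this oxygen, on a saturated carbon whose other neighbours are saturated ring carbon, has a measurable effect: a 3.0-fold higher number from compound 3 to compound 4 (0.47 log units; beyond the scatter). Until now the exchange was known only from a step at a different oxygen, which left the number unchanged within the scatter. The exchange therefore cannot be treated as neutral across the series, and its size differs between the two cores that carry it: the same change on two cores in this assay, a 1.0-fold higher number (0.00 log units; within the scatter) from compound 1 to compound 2 and a 3.0-fold higher number (0.47 log units; beyond the scatter) from compound 3 to compound 4, 2.9-fold (0.47 log units) apart, beyond the scatter of two such steps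

On these data alone, it remains open whether the step at this oxygen would be of the same size on a core without the tert-butyldimethylsilyl group. Also open, as far as these compounds go, is how a longer ester such as benzoyloxy, a methyl ether or an amine at this carbon would compare with acetoxy and hydroxy.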